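This account rests on a few compounds, and the source may have more. Where it says the series, first, only, none or still open, it means among the compounds named here.

The compounds measured in an in vitro functional assay on HEK293-A cells for antagonist activity at metabotropic glutamate receptor 5 (Rattus norvegicus), read by calcium flux (on this read-out lower numbers stand for stronger inhibition and higher numbers for weaker inhibition), so far:

compound 1, `COc1ccccc1C(=O)Nc1cccc(NC(=O)c2ccccc2Cl)c1`, gives > 30000 nM
compound 2, `COc1ccccc1C(=O)Nc1cccc(NC(=O)c2ccc(Cl)cc2)c1`, gives > 30000 nM
compound 3, `COc1ccccc1C(=O)Nc1cccc(NC(=O)C2CCCCC2)c1`, gives > 30000 nM

Each of these three readings is a limit of this assay and not a number. The reading for compound 1 is a limit. The reading for compound 2 is a limit. The reading for compound 3 is likewise a limit, so compound 3 stands at the edge of what this assay can report, just as the other two do. The three differ only in the group on the second carbonyl carbon, and the steps between them, a step that the two limits leave unreadable from compound 1 to compound 2, a step that the two limits leave unreadable from compound 1 to compound 3 and a step that the two limits leave unreadable from compound 2 to compound 3, cannot be sized, since (the limit of > 30000 nM in this assay, at which 3 of the 3 values shown sit).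

Compound 4, `COc1ccccc1C(=O)Nc1cccc(NC(=O)C2CC2)c1`, differs from compound 3 in one place: cyclopropyl in place of cyclohexyl on a carbonyl carbon. Among the compounds with values here, no measured step covers this exchange, and the three steps that exist are unreadable, so they neither support nor argue against a change in this assay. With every neighbour sitting at the limit, the step that the limit leaves unreadable from compound 3 to compound 4 is expected to be small or unreadable. Compound 4 is therefore estimated to give about 40000 nM in this assay, within a range from 10000 nM to 150000 nM, and most probably again only a limit.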

Compound 4, half-maximal inhibitory concentration: > 30000 nM
Compound 4 ended at the assay's limit; the forecaster's own chance of this, stated with the estimate: 85%; the middle value is on the limit's open side.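

Within the data shown here, compound 4 also reads as a limit and not a number, so no step among compound 1, compound 2, compound 3 and compound 4 can be read, because all four readings sit at the same limit: the limit of > 30000 nM in this assay, at which 4 of the 4 values shown sit.

The compounds shown leave open whether any group on this carbonyl carbon would give measurable inhibition, and how far these four groups differ.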